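From pyridin-3-yl to pyridin-4-yl in compound 4

The compounds below may be only part of what the source reports. "The series", "measured", "known", "first", "only" and "open" are said of these compounds alone.

In a functional assay on SMMC-7721 cells (Homo sapiens) for cytotoxicity, read by MTT assay, with a stated time of 24 h (a lower number here means a stronger inhibitor, a higher number a weaker inhibitor), compound 1 `COc1ccc(/C=C2\CN(C)C/C(=C\c3cccnc3)C2=O)c(OC)c1OC` gives 13700 nM and compound 2 `CN1C/C(=C\c2cccnc2)C(=O)/C(=C/c2ccccc2F)C1` gives 5420 nM. Compound 3 `CN1C/C(=C\c2cccnc2)C(=O)/C(=C/c2ccccc2C(F)(F)F)C1` gives 3900 nM, a number within the scatter of compound 2 and clearly lower than that of compound 1.

Compound 4 `CN1C/C(=C\c2ccncc2)C(=O)/C(=C/c2ccccc2C(F)(F)F)C1` has not yet been measured. Its structure departs from compound 3 as follows: pyridin-4-yl in place of pyridin-3-yl on a double-bonded chain carbon bound to a double-bonded ring carbon. The change is pyridin-4-yl in place of pyridin-3-yl on a double-bonded chain carbon bound to a double-bonded ring carbon.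

Going by the values given here, no measured step covers this exchange. Among the compounds with values here, the only step available, a 1.4-fold lower number from compound 2 to compound 3 (0.14 log units; within the scatter), is trifluoromethyl in place of fluoro on an aromatic carbon, so it bears on the question only indirectly, as one single-place change that stayed small in this assay. On that thin evidence, no step beyond the scatter is expected, and no direction can be favoured. The expected step is a 1.1-fold lower number from compound 3 to compound 4 (0.05 log units; within the scatter). For compound 4 the estimated value is 3500 nM, with an expected range from 1600 nM to 7800 nM.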

Compound 4, half-maximal inhibitory concentration: 4100 nM
For compound 4 the middle estimate is 1.2-fold (0.07 log units) below the measured one; measured number inside the range.
By their numbers in this assay, from the lowest: compounds 3, 4 and 2 (each within the scatter of the next); then compound 1.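

Exchanging the groups at this place, on a double-bonded chain carbon bound to a double-bonded ring carbon, gives a 1.1-fold higher number from compound 3 to compound 4 (0.02 log units; within the scatter) in this assay. Compounds 1, 2 and 3 all carry pyridin-3-yl here and so said nothing about this place, whereas this pair shows that, with the trifluoromethyl-bearing aromatic ring kept, pyridin-3-yl and pyridin-4-yl cannot be told apart in this assay. No measurement at hand bears on why the exchange leaves the number within the scatter.

The compounds shown leave open whether the same exchange would stay as small with the fluoro group of compound 2 or the aromatic group of compound 1 in the core. They also leave open how a plain phenyl ring, or a phenyl ring carrying a carboxylic acid, would behave at this place.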